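A few compounds are considered here, and "the series" means these few. Any claim that something is new, unique, unknown or untested is made for them only; others in the source may bear on it.

The three measured compounds share one core and differ only in the aromatic group attached to it. Compound 1 `NS(=O)(=O)c1ccc(-c2nc(C(c3ccc(F)cc3)c3ccc(F)cc3)sc2CC(=O)O)cc1` gives in an in vitro functional assay on HEK285-7 cells for antagonist activity at prostaglandin D2 receptor 2 (Homo sapiens), read by BRET and beta-arrestin recruitment (on this read-out higher numbers stand for larger maximal responses and lower numbers for smaller maximal responses), a value of 80%. Compound 2 `O=C(O)Cc1sc(C(c2ccc(F)cc2)c2ccc(F)cc2)nc1-c1ccnc(Cl)c1` gives in this assay 80%, and compound 3 `O=C(O)Cc1sc(C(c2ccc(F)cc2)c2ccc(F)cc2)nc1-c1cn[nH]c1` gives in this assay 80%. Compound 3 therefore stands level with the other two at the digits shown: the step of no change at the digits printed from compound 1 to compound 3 (within the scatter) and the step of no change at the digits printed from compound 2 to compound 3 (within the scatter) both lie within the scatter, and so does the step of no change at the digits printed from compound 1 to compound 2 (within the scatter). Three different aromatic groups at this position thus gave the same maximal response.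

Compound 4 `Cc1cc(-c2nc(C(c3ccc(F)cc3)c3ccc(F)cc3)sc2CC(=O)O)cnc1N` arises from compound 3 by a single change: 6-amino-5-methylpyridin-3-yl in place of 1H-pyrazol-4-yl on an aromatic carbon. All three measured steps bear on this change, since each of them also swapped the aromatic group at this same attachment point, and none of them moved the read-out beyond the scatter. A fourth such swap is therefore expected to behave alike, and the expected step of no change at the digits printed from compound 3 to compound 4 (within the scatter) is none beyond the scatter. Compound 4 is estimated to give 80% in this assay, with a range from 70% to 90%.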

Compound 4, largest response reached (reported as efficacy), in percent of the reference or control that the assay uses: 80%
Compound 4: the middle estimate sits on the measured number at the digits printed, and the stated range covers the measured number.
By their numbers in this assay, from the lowest: compounds 1, 2, 3 and 4 (each within the scatter of the next).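

Compound 4 places a six-membered aromatic ring carrying an amino and a methyl group on this carbon, with 8 heavy atoms where the 1H-pyrazol-4-yl group of compound 3 has 5, and 2 hydrogen-bond acceptors where that group has 1, yet this assay records no change at the digits printed from compound 3 to compound 4 (within the scatter). Measured against the two other groups, the 6-amino-5-methylpyridin-3-yl group again leaves the maximal response in place, with no change at the digits printed from compound 2 to compound 4 (within the scatter) when it stands in for 2-chloropyridin-4-yl and no change at the digits printed from compound 1 to compound 4 (within the scatter) when it stands in for 4-sulfamoylphenyl, so this position has now tolerated four different aromatic groups, including the first aminopyridine, with no separation among them. Nothing available here accounts for this sameness.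

All four groups attach through an aromatic ring, so the compounds shown leave open whether a saturated ring such as piperidine, or an open chain such as propyl, on this same carbon would give the same maximal response. They also leave open whether a longer chain ending in the carboxylic acid, in place of the carboxymethyl group, would hold this response.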